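Shortening the alkyne chain on two uridine-type cores

The source may hold more compounds than are shown below. What is called first, only, known or untested is meant among the compounds shown, and "the series" means these compounds.

Compound 1 `C#Cc1cn(C2O[C@H](CO)[C@@H](O)[C@@H]2O)c(=O)[nH]c1=O` carries an ethynyl group on its core. In a functional assay on L1210 cells (Mus musculus) (a lower number here means a stronger inhibitor, a higher number a weaker inhibitor), compound 1 gives 45 ug/mL. Compound 2 `CCC#Cc1cn(C2O[C@H](CO)[C@@H](O)[C@@H]2O)c(=O)[nH]c1=O` has a but-1-yn-1-yl group instead. In this assay compound 2 reaches only the limit > 1000 ug/mL. The change hydrogen in place of ethyl on a triple-bonded carbon therefore gave an at least 22-fold lower number from compound 2 to compound 1 (1.34 log units; beyond the scatter). Compound 3 `CCCC#Cc1cn([C@H]2C[C@H](O)[C@@H](CO)O2)c(=O)[nH]c1=O` sits on a different core; the difference between the two cores is not broken down here. In this assay compound 3 also reaches only the limit > 1000 ug/mL. Compound 4 `CC#Cc1cn([C@H]2C[C@H](O)[C@@H](CO)O2)c(=O)[nH]c1=O` is not yet measured and differs from compound 3 by hydrogen in place of ethyl on a saturated chain carbon bound to a triple-bonded carbon, the same kind of change, but at a saturated chain carbon rather than at the triple-bonded carbon. The step is expected to be an at least 5.0-fold lower number from compound 3 to compound 4 (0.69 log units; beyond the scatter), resting on the large gain seen as an at least 22-fold lower number from compound 2 to compound 1 (1.34 log units; beyond the scatter). Compound 4 is thus estimated at 200 ug/mL, between 20 ug/mL and 1000 ug/mL.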

Compound 4, concentration for 50% inhibition: 164 ug/mL
Beside the measured number, compound 4's estimate is 1.2-fold (0.09 log units) above it; the measured number falls inside the stated range.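

Shortening the chain on the second core also lowers the number in this assay, with an at least 6.0-fold lower number from compound 3 to compound 4 (0.78 log units; beyond the scatter), so the direction of the change carries over from one core to the other in these two pairs. How far the size carries over stays unsettled, since each pair starts from a limit and the two steps cannot be ranked: the same change on two cores in this assay, an at least 22-fold lower number (1.34 log units; beyond the scatter) from compound 2 to compound 1 and an at least 6.0-fold lower number (0.78 log units; beyond the scatter) from compound 3 to compound 4; the limit leaves it open whether they differ. The value for compound 2 and the value for compound 3 are limits of the assay and not numbers: the limit of > 1000 ug/mL in this assay, at which 2 of the 4 values shown sit.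

Still open, on these data alone, is how an amine at the end of the chain would read in this assay. Also open, as far as these compounds go, is how the ethynyl group of compound 1 would read on the core of compound 4.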